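This account rests on a few compounds, and the source may have more. Where it says the series, first, only, none or still open, it means among the compounds named here.

Measured in a physicochemical assay for solubility, read by spectrophotometry, in phosphate buffer, with a stated time of 18 h, at pH 7.4; on this read-out higher numbers stand for higher solubility and lower numbers for lower solubility:
- compound 1 `CCc1ccc(-c2nc3c(c(C)nn3-c3ccccc3)c(-c3cccc(O)c3)c2C#N)cc1`: 18000 nM
- compound 2 `Cc1nn(-c2ccccc2)c2nc(-c3ccc4ccccc4c3)c(C#N)c(-c3ccccc3O)c12`: 1800 nM

Of these two numbers, compound 2 stands lowest at 1800 nM. The nearest number belongs to compound 1 at 18000 nM, and the gap between them lies beyond the scatter. Within the data shown here, the two compounds differ in more than one place, so their values show no single structural step.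

The next compound, compound 3 `Cc1nn(-c2ccccc2)c2nc(-c3ccc([N+](=O)[O-])cc3)c(C#N)c(-c3ccccc3O)c12`, is built from compound 2 by one change: 4-nitrophenyl in place of naphthalen-2-yl on an aromatic carbon, next to the ring nitrogen and ortho to a cyano group (4-nitrophenyl in place of naphthalen-2-yl on an aromatic carbon). The 2-hydroxyphenyl group and the rest of the shared core stay as they are.

Among the measured compounds shown here, no measured pair shows this change, so the expectation rests on little. For the measured compounds named here, compound 2 holds the lower of only two numbers, with 1800 nM, which leaves more room to expect a rise than a fall. A small rise in this assay, about the size of the usual scatter, is expected, estimated as a 1.9-fold higher number from compound 2 to compound 3 (0.29 log units; within the scatter). The estimated value for compound 3 is 3500 nM, with an expected range from 1000 nM to 12000 nM.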

Compound 3, solubility: 6000 nM
Compound 3: middle estimate off by 1.7-fold (0.23 log units), on the low side; measured number inside the range.
By their numbers in this assay, from the lowest: compound 2; then compound 3; then compound 1.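

In this assay, the position next to the ring nitrogen and ortho to a cyano group now has its first readable step: 4-nitrophenyl in place of naphthalen-2-yl gives a 3.3-fold higher number from compound 2 to compound 3 (0.52 log units; beyond the scatter). With the 2-hydroxyphenyl group and the rest of the shared core unchanged, the number therefore responds to the group at this position, in a swap that removes one six-membered aromatic ring of carbon only and brings in 2 hydrogen-bond acceptors. This is a single modest step, and no measurement here says which of those differences matters or gives a reason for the step.

On these data alone, it remains open whether the step belongs to the nitro group, to the loss of the second ring, or to both, and a plain phenyl or a phenyl carrying an amine or a carboxylic acid at this position would begin to separate these readings. Compound 1 differs from both compound 2 and compound 3 in more than one place, so the separate contributions of its other substituent and of its hydroxyl placement also remain unresolved.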